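Amino for Nitro on Two Triazole Isomers

The source may hold more compounds than are shown below. What is called first, only, known or untested is meant among the compounds shown, and "the series" means these compounds.

Compound 1 `COc1ccc(Cn2nncc2-c2cc(OC)c(OC)c(OC)c2)cc1[N+](=O)[O-]` and compound 2 `COc1ccc(Cn2nncc2-c2cc(OC)c(OC)c(OC)c2)cc1N` share one core and differ in a single place. In a functional assay on K562 cells (Homo sapiens) for cytotoxicity, read by MTT assay, with a stated time of 5 days (a lower number here means a stronger inhibitor, a higher number a weaker inhibitor), compound 1 gives only a limit of the assay, > 10000 nM. In this assay compound 2 gives 730 nM. The change between them is amino in place of nitro on an aromatic carbon, and it made an at least 13-fold lower number from compound 1 to compound 2 (1.13 log units; beyond the scatter). Compound 3 `COc1ccc(-c2cnnn2Cc2cc(OC)c(OC)c(OC)c2)cc1[N+](=O)[O-]` has the same atoms as compound 1 joined differently; the difference between the two cores is not broken down here. In this assay compound 3 gives only a limit, > 10000 nM. Compound 4 `COc1ccc(-c2cnnn2Cc2cc(OC)c(OC)c(OC)c2)cc1N` carries the same change on the core of compound 3, (amino in place of nitro on an aromatic carbon), at a place described in the same words. Because two of the three values sit at the limit (the limit of > 10000 nM in this assay, at which 2 of the 3 values shown sit), the measured step is only a floor. The expected step is an at least 6.6-fold lower number from compound 3 to compound 4 (0.82 log units; beyond the scatter), resting on an at least 13-fold lower number from compound 1 to compound 2 (1.13 log units; beyond the scatter). Compound 4 is expected near 1500 nM, between 400 nM and 8000 nM.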

Compound 4, half-maximal inhibitory concentration: 380 nM
Compound 4: the middle estimate sits 3.9-fold (0.60 log units) above what was measured; measured number outside the range, below it.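

In this assay, amino in place of nitro lowers the number on the second core as well, giving an at least 26-fold lower number from compound 3 to compound 4 (1.42 log units; beyond the scatter), so the change carried over between these two cores. It does not show that the gain has the same size on both cores, or how the two steps rank: the same change on two cores in this assay, an at least 13-fold lower number (1.13 log units; beyond the scatter) from compound 1 to compound 2 and an at least 26-fold lower number (1.42 log units; beyond the scatter) from compound 3 to compound 4; the limit leaves it open whether they differ. Each step is only a floor, since the nitro compounds give a limit and not a number: the limit of > 10000 nM in this assay, at which 2 of the 4 values shown sit.

The compounds shown leave open how a hydroxyl, a methylamino or an acetamide group would compare with amino on this aromatic carbon. They also leave open whether the change would carry over to any core beyond these two.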